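The source may report more compounds than this note shows. Statements on the series, on what has been measured and on what is new or still open speak of the compounds shown alone.

Measured compounds in an assay on CHO cells for displacement of a labelled ligand from adenosine receptor A2b (Homo sapiens), read by scintillation counting, with a stated time of 75 min; a higher number here means a weaker inhibitor, a lower number a stronger inhibitor:
compound 1, `COc1cccc(/C=C/C(=O)Nc2nc3ccccc3c(=O)s2)c1`, gives 679 nM.
compound 2, `O=C(COc1cccc(Cl)c1)Nc1nc2ccccc2c(=O)s1`, gives > 1000 nM, which is a limit of the assay.
compound 3, `O=C(CCc1ccccc1Br)Nc1nc2ccccc2c(=O)s1`, gives > 1000 nM, which is also a limit of the assay.

Among the measured compounds shown here, compound 1 thus stands as the only compound in the set with a numerical inhibition constant; the other two values are only limits, as noted in the limit of > 1000 nM in this assay, at which 2 of the 3 values shown sit. For the measured compounds named here, no two of the measured compounds differ from each other in a single place, so no measured step exists to lean on.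

Compound 4, `O=C(/C=C/c1cccc(Cl)c1)Nc1nc2ccccc2c(=O)s1`, is the next compound to be measured in this assay. Against compound 1 it shows (chloro in place of methoxy on an aromatic carbon), that is, chloro in place of methoxy on an aromatic carbon, the rest of the structure being kept. Compound 2 and compound 3, the other two compounds carrying a halogen on the aromatic ring, show only limits, and their linkers differ from that of compound 1 and compound 4 in more than one place, so they give no direct measure of this single exchange.

The step from compound 1 to compound 4 is expected to be small, most likely within the scatter, with a slight lean toward a weaker inhibitor, a 1.3-fold higher number from compound 1 to compound 4 (0.10 log units; within the scatter). Compound 4 is accordingly estimated at 850 nM in this assay, within a range of 300 nM to 2500 nM.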

Compound 4, inhibition constant: > 1000 nM
Compound 4 was reported as a limit (the forecaster's own chance of this, stated with the estimate: 35%); middle value at least 1.1-fold (0.07 log units) away from the limit.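

In this assay, among the compounds shown here, the change from 3-methoxyphenyl to 3-chlorophenyl gives the first step that can be read at a single place, with the rest of the structure kept: an at least 1.4-fold higher number from compound 1 to compound 4 (0.16 log units; that floor lies within the scatter). Compound 4 gives > 1000 nM, which is a limit of the assay, so the step has a floor but no measured size, and that floor does not by itself separate chloro from methoxy at this position. Compound 1 therefore remains the only compound here with a numerical inhibition constant, and chloro on this aromatic carbon adds a further value at the same limit: the limit of > 1000 nM in this assay, at which 3 of the 4 values shown sit.

Going by these compounds, how far compound 4 lies past its limit remains open, and with it whether this exchange matters at all or only appears to within the scatter. Also open, on these data alone, is what a hydroxy group, an amine or a carboxylic acid would give on the same aromatic carbon, and whether a longer alkoxy chain in place of methoxy would keep a numerical value.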